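Replacing a hydroxyphenyl by a methylsulfanylphenyl

The source may report more compounds than this note shows. Statements on the series, on what has been measured and on what is new or still open speak of the compounds shown alone.

Of the compounds shown here, three sharing one core have been measured in a physicochemical assay for lipophilicity, measured as octanol-water partition; a lower number here means a more polar compound, a higher number a more lipophilic compound. Compound 1 `O=C(COc1cccc2ccccc12)N/N=C/c1ccccc1[N+](=O)[O-]` gives 3.97, compound 2 `C/C(=N\NC(=O)COc1cccc2ccccc12)c1ccc(O)cc1O` gives 4.31, and compound 3 `O=C(COc1cccc2ccccc12)N/N=C/c1ccccc1O` gives 3.73, the lowest of the three numbers, though its distance to compound 1 lies within the scatter and only its distance to compound 2 lies beyond it. Going by the values given here, the one step between compounds differing in a single place, a number 0.24 log units lower from compound 1 to compound 3 (within the scatter), was within the scatter.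

Compound 4 `CSc1ccc(/C=N/NC(=O)COc2cccc3ccccc23)cc1` has not yet been measured in this assay. It differs from compound 3 in one place: 4-(methylsulfanyl)phenyl in place of 2-hydroxyphenyl on a carbon with a double bond to nitrogen. Among the compounds with values here, no measured step swaps an entire hydroxyphenyl for a methylsulfanylphenyl, so the step from compound 1 to compound 3 bears only loosely on it; that step removed a nitro for a hydroxy and hardly moved the number. Here a ring with one hydrogen-bond donor leaves and a ring with none enters, so compound 4 is expected to sit higher than compound 3, with an estimated step of a number 1.07 log units higher from compound 3 to compound 4 (beyond the scatter). Compound 4 is therefore estimated at 4.8, in the range 4.3 to 5.3.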

Compound 4, partition coefficient: 4.11
Compound 4: middle estimate off by 0.69 log units, on the high side; the whole stated range lies above it.
By their numbers in this assay, from the lowest: compounds 3, 1, 4 and 2 (each within the scatter of the next, the first and the last beyond it).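

Replacing the ring on this carbon with a double bond to nitrogen gives a number 0.38 log units higher from compound 3 to compound 4 (beyond the scatter) in this assay and so yields a shift beyond the scatter, which the earlier step from nitro to hydroxy did not. The shift is modest even though 2-hydroxyphenyl with 1 hydrogen-bond donor gives way to 4-(methylsulfanyl)phenyl with 0 hydrogen-bond donors, so at this position the change in donor count goes with only a small move in the number. No evidence is available that explains the size of this step.

The swap changes both the group on the ring and its place in the name, and the compounds shown cannot separate the two; a 4-hydroxyphenyl at this carbon would bear on that. From the compounds shown here alone, how a ring carrying an amine or a carboxylic acid would read in this assay also remains open.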